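This account rests on a few compounds, and the source may have more. Where it says the series, first, only, none or still open, it means among the compounds named here.

Compound 1, `Cn1c(-c2ccccc2)cnc1NC(=O)c1cccc(Cl)c1`: > 50000 nM
Compound 2, `COc1ccc(-c2cnc(NC(=O)c3ccc(Br)cc3)n2C)cc1`: > 100000 nM

Of the compounds shown here, two have been measured in a toxicity assay on THP-1 cells (Homo sapiens) for inhibition (on this read-out lower numbers stand for higher toxicity in this test and higher numbers for lower toxicity in this test), and neither gave a number. Compound 1 reached only a limit of the assay, > 50000 nM, the limit given by the limit of > 50000 nM in this assay, at which 1 of the 2 values shown sits. Compound 2 likewise gave only a limit, > 100000 nM, the limit given by the limit of > 100000 nM in this assay, at which 1 of the 2 values shown sits. Compound 2 therefore stands at a limit, with no numerical value, and the one other compound shown is at a limit as well; no step between measured compounds can be counted.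

The unmeasured compound 3, `Cn1c(-c2ccccc2)cnc1NC(=O)c1ccc(Br)cc1`, differs from compound 2 by hydrogen in place of methoxy on an aromatic carbon. Among the compounds with values here, no measured pair shows what hydrogen in place of methoxy on an aromatic carbon does in this assay, so the step can only be expected, not read off. With both measured compounds at limits, the expected step is none beyond the scatter: a number no higher from compound 2 to compound 3 (the limit leaves the size open). Compound 3 is expected to give about 100000 nM, between 30000 nM and 300000 nM, and most probably the assay will again report only a limit rather than a number.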

Compound 3, half-maximal cytotoxic concentration: > 100000 nM
Compound 3: a limit, no number; the forecaster's own chance of this, stated with the estimate: 85%; the middle value lies on the limit itself.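

Compound 3 gave only a limit, > 100000 nM, so no step can be read from compound 2 to compound 3 or from compound 1 to compound 3. The compounds shown leave open whether the change from 4-methoxyphenyl to phenyl has any effect, and at what concentration, if any, compound 1, compound 2 or compound 3 would give a number in this assay.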